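The source may hold more compounds than are shown below. What is called first, only, known or untested is meant among the compounds shown, and "the series" means these compounds.

Measured so far in a functional assay, with a stated time of 30 min, in the absence of a further agent; a higher number here means a weaker inhibitor, a lower number a stronger inhibitor:

compound 1, `O=C(Nc1nnc(-c2cccc(O)c2O)s1)C1CCCCC1`: 19900 nM
compound 2, `O=C(Nc1nnc(-c2ccc(O)c(O)c2)s1)c1ccc(Cl)cc1`: 53000 nM

Compound 2 stands at the higher of the two numbers in this assay; compound 1 gives the lower number, and the gap between them lies beyond the scatter. The two measured compounds differ in more than one place, so nothing more than this comparison of their two values can be drawn from them.

Compound 3, `Cc1ccc(C(=O)Nc2nnc(-c3ccc(O)c(O)c3)s2)cc1`, has not yet been measured in this assay. It differs from compound 2 by methyl in place of chloro on an aromatic carbon. Among the measured compounds shown here, no measured pair shows what this exchange does in this assay, so there is no step of the same kind to lean on. The exchange swaps one heavy atom for another on the same aromatic carbon and adds no donor or acceptor. On that basis the step of a 1.1-fold lower number from compound 2 to compound 3 (0.03 log units; within the scatter) is expected to stay within the scatter, with no direction favoured. Compound 3 is therefore estimated at 50000 nM, in the range 20000 nM to 120000 nM.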

Compound 3, half-maximal inhibitory concentration: 34000 nM
Beside the measured number, compound 3's estimate is 1.5-fold (0.17 log units) above it, and the stated range covers the measured number.
By their numbers in this assay, from the lowest: compounds 1, 3 and 2 (each within the scatter of the next, the first and the last beyond it).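

In this assay, among the compounds shown here, the exchange of 4-chlorophenyl to 4-methylphenyl gives a 1.6-fold lower number from compound 2 to compound 3 (0.19 log units; within the scatter) and is the first step that can be read at a single place, as compound 1 and compound 2 differ in more than one. Methyl in place of chloro on this aromatic carbon, para to a large group, therefore leaves the two values indistinguishable, and this position accepts either group without a change that stands clear of the scatter. Nothing at hand accounts for this result or for the size of the step.

Chloro and methyl each count a single heavy atom and neither counts a hydrogen-bond donor or acceptor, so the step leaves open what an amine, a carboxylic acid or a longer chain such as propyl would do at this position. Also open is whether the same exchange would give a similar step on any other background: compound 2 and compound 3 are the only pair shown that differ in one place.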